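This account rests on a few compounds, and the source may have more. Where it says the series, first, only, none or still open, it means among the compounds named here.

Measured so far in an ADME assay on MT4 cells (Homo sapiens) for cytotoxicity, read by MTT assay, with a stated time of 5 days; on this read-out higher numbers stand for lower toxicity in this test and lower numbers for higher toxicity in this test:
compound 1 `N#Cc1ccc(Nc2nccc(OCc3ccccc3Br)n2)cc1` gives 130000 nM
compound 2 `Cc1ccccc1COc1ccnc(Nc2ccc(C#N)cc2)n1` gives 12000 nM

For the measured compounds named here, compound 2 stands at the lowest of the two numbers; its only neighbour is compound 1, and the one measured step, an 11-fold lower number from compound 1 to compound 2 (1.03 log units; beyond the scatter), separates them, well beyond the scatter.

Compound 3 `N#Cc1ccc(Nc2nccc(OCc3cccc(C#N)c3)n2)cc1` is not yet measured. Its change from compound 2 is 3-cyanophenyl in place of 2-methylphenyl on a saturated chain carbon bound to an oxygen on an aromatic ring. Going by the values given here, no measured step covers this exchange: the single step available, an 11-fold lower number from compound 1 to compound 2 (1.03 log units; beyond the scatter), concerns a different pair of groups on the same ring and shows only that a change of substituent at this position can move this assay by a large amount in either direction. The direction for compound 3 is therefore open, and the expectation is wide. Compound 3 is expected near 40000 nM, with a range of 8000 nM to 200000 nM; this would mean a step of a 3.3-fold higher number from compound 2 to compound 3 (0.52 log units; beyond the scatter), estimated with low confidence.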

Compound 3, half-maximal cytotoxic concentration: 4100 nM
Compound 3: the middle estimate sits 9.8-fold (0.99 log units) above what was measured; the measured number lies below the stated range.
By their numbers in this assay, from the lowest: compound 3; then compound 2; then compound 1.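

In this assay, 3-cyanophenyl in place of 2-methylphenyl on the saturated chain carbon gives a 2.9-fold lower number from compound 2 to compound 3 (0.47 log units; beyond the scatter) and shows that a nitrile-bearing phenyl group at this place can carry the number lower than either earlier group did. Set against the 2-bromophenyl group, the same group gives a 32-fold lower number from compound 1 to compound 3 (1.50 log units; beyond the scatter) as the widest span so far at this position, leaving compound 3 with the lowest number of the three and so the highest toxicity in this test. No measurement is available that would account for this order of the three groups.

The exchange alters both the substituent and its place on the phenyl ring, and the compounds shown cannot separate these two changes. Going by these compounds, how an amine or a carboxylic acid in place of the nitrile would read in this assay also remains open.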